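Shifting a Phenol Hydroxyl from Compound 3 to Compound 4

The source may report more compounds than this note shows. Statements on the series, on what has been measured and on what is new or still open speak of the compounds shown alone.

The three measured compounds, all tested in a functional assay on T47D cells (Homo sapiens) for cytotoxicity, read by CCK-8 assay; a higher number here means a weaker inhibitor, a lower number a stronger inhibitor:

Compound 1 `Oc1cccc(-c2cc(-c3cccs3)cc(-c3ccccc3O)n2)c1`: compound 1 gives > 50000 nM, a limit of the assay.
Compound 2 `Oc1ccc(-c2cc(-c3cccs3)cc(-c3ccccc3O)n2)cc1`: compound 2 gives > 50000 nM, also a limit.
Compound 3 `Oc1ccc(-c2cc(-c3ccoc3)cc(-c3cccc(O)c3)n2)cc1`: compound 3 gives 2610 nM.

Compound 1 and compound 2 differ by 4-hydroxyphenyl in place of 3-hydroxyphenyl on an aromatic carbon. The step that the two limits leave unreadable from compound 1 to compound 2 cannot be sized because both values sit at the limit of > 50000 nM in this assay, at which 2 of the 3 values shown sit. Compound 3 differs from compound 1 in more than one place, and the difference between the two cores is not broken down here.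

Compound 4 `Oc1ccc(-c2cc(-c3ccoc3)cc(-c3ccc(O)cc3)n2)cc1` is the unmeasured partner of compound 3; it arises through (4-hydroxyphenyl in place of 3-hydroxyphenyl on an aromatic carbon). This is the same kind of change as that from compound 1 to compound 2, not the same one: there the place was meta to a 2-hydroxyphenyl group and meta to a thiophen-2-yl group, here it is meta to a 4-hydroxyphenyl group and meta to a furan-3-yl group.

Among the measured compounds shown here, since the one measured example of this change gives no readable size, the expectation for compound 4 rests on compound 3 at 2610 nM, with an expected step of a 1.0-fold lower number from compound 3 to compound 4 (0.00 log units; within the scatter) and wide uncertainty. Compound 4 is thus estimated at 2600 nM, between 800 nM and 9000 nM.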

Compound 4, half-maximal inhibitory concentration: 3460 nM
Compound 4: the middle estimate sits 1.3-fold (0.12 log units) below what was measured; the measured number falls inside the stated range.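

In this assay, among the compounds shown here, the one readable example of 4-hydroxyphenyl in place of 3-hydroxyphenyl is a 1.3-fold higher number from compound 3 to compound 4 (0.12 log units; within the scatter), so on this core the change makes no difference that can be told from ordinary repeat-to-repeat variation. The same change on the core of compound 1 cannot be sized, because compound 1 and compound 2 both give only a limit of the assay, not a number: the limit of > 50000 nM in this assay, at which 2 of the 4 values shown sit. The change therefore has a readable size on just one core, which shows that it can be made there without a detectable effect but does not show that it would be equally silent on other cores in this series.

The compounds shown leave open whether furan-3-yl and thiophen-2-yl are interchangeable when everything else on the core stays the same. They also leave open what an amine or a carboxylic acid in place of the phenol hydroxyl would do in this assay.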